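Ester chain length and cytotoxicity on lung cancer cells

This account rests on a few compounds, and the source may have more. Where it says the series, first, only, none or still open, it means among the compounds named here.

Measured so far:
compound 1 `CCCOC(=O)CCC(=O)N1CCN(CCCOc2cc3c(Nc4ccc(F)c(Cl)c4)ncnc3cc2OC)CC1` gives 70.4%
compound 2 `CCCCOC(=O)CCC(=O)N1CCN(CCCOc2cc3c(Nc4ccc(F)c(Cl)c4)ncnc3cc2OC)CC1` gives 64.1%
compound 3 `CCCCCCCCCOC(=O)CCC(=O)N1CCN(CCCOc2cc3c(Nc4ccc(F)c(Cl)c4)ncnc3cc2OC)CC1` gives 10.3%

All three were tested in a functional assay on A549 cells (Homo sapiens) for cytotoxicity, read by MTT assay, with a stated time of 24 h, tested at 60 uM; a higher number here means a weaker effect of the compound at the concentration tested, a lower number a stronger effect. They share one core and differ only in the ester chain. Compound 2 carries methyl in place of hydrogen on a saturated chain carbon, three bonds along the chain from an oxygen next to a carbonyl group, and the step of a number 6.3 percentage points lower from compound 1 to compound 2 (within the scatter). Compound 3 carries hexyl in place of hydrogen on a saturated chain carbon, three bonds along the chain from an oxygen next to a carbonyl group, and the step of a number 60.1 percentage points lower from compound 1 to compound 3 (beyond the scatter); likewise a number 53.8 percentage points lower from compound 2 to compound 3 (beyond the scatter).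

Compound 4 `CCCCCCCCCCOC(=O)CCC(=O)N1CCN(CCCOc2cc3c(Nc4ccc(F)c(Cl)c4)ncnc3cc2OC)CC1` has not yet been measured. Relative to compound 3 it carries methyl in place of hydrogen on a saturated chain carbon, nine bonds along the chain from an oxygen next to a carbonyl group. This is the same kind of change as from compound 1 to compound 2, but placed nine bonds rather than three bonds along the chain from the oxygen next to the carbonyl group. Because that earlier step was a number 6.3 percentage points lower from compound 1 to compound 2 (within the scatter), the step from compound 3 to compound 4 is expected to be small as well, estimated at a number 2.3 percentage points lower from compound 3 to compound 4 (within the scatter). For compound 4 the value in this assay is expected to be about 8%, roughly between 2% and 20%.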

Compound 4, a percentage reported as activity, at one concentration (the size of the read-out at that concentration, not a potency): 3.9%
For compound 4 the middle estimate is 4.1 percentage points above the measured one; measured number inside the range.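

Adding a methyl gives a number 6.4 percentage points lower from compound 3 to compound 4 (within the scatter), which matches the earlier methyl step: the same change on two cores in this assay, a number 6.3 percentage points lower (within the scatter) from compound 1 to compound 2 and a number 6.4 percentage points lower (within the scatter) from compound 3 to compound 4, 0.1 percentage points apart, within the scatter of two such steps. The hexyl change gives a number 60.2 percentage points lower from compound 2 to compound 4 (beyond the scatter), which likewise matches its earlier counterpart: the same change on two cores in this assay, a number 60.1 percentage points lower (beyond the scatter) from compound 1 to compound 3 and a number 60.2 percentage points lower (beyond the scatter) from compound 2 to compound 4, 0.1 percentage points apart, within the scatter of two such steps. With heptyl giving a number 66.5 percentage points lower from compound 1 to compound 4 (beyond the scatter) in this assay, lengthening the ester chain carries over between these compounds, but these few pairs do not show that it would on a core outside this set, nor why the chain has this effect.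

The compounds shown leave open what a longer chain, or a chain ending in an amine or a carboxylic acid, would give. A chain of intermediate length could show where between compound 2 and compound 3 the large change sets in.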